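The compounds below may be only part of what the source reports. "The series", "measured", "known", "first", "only" and "open" are said of these compounds alone.

In a functional assay on HCC827 cells (Homo sapiens) for inhibition, read by fluorescence, with a stated time of 72 h (on this read-out lower numbers stand for stronger inhibition of growth and higher numbers for weaker inhibition of growth), compound 2 (`CCCCCCn1cnc2c(Nc3cc(OC)cc(OC)c3)nc(N[C@H]3CC[C@H](N)CC3)nc21`) gives 9100 nM and compound 1 (`COc1cc(Nc2nc(N[C@H]3CC[C@H](N)CC3)nc3c2ncn3CCC(C)C)cc(OC)c1`) gives 11200 nM. Among the measured compounds shown here, these are the only two numbers so far, and they lie within the scatter of each other, so compound 2 stands level with compound 1.

Compound 3 (`CCCCn1cnc2c(Nc3cc(OC)cc(OC)c3)nc(N[C@H]3CC[C@H](N)CC3)nc21`) differs from compound 2 in one place: hydrogen in place of ethyl on a saturated chain carbon, four bonds along the chain from an aromatic nitrogen. Hydrogen stands in place of ethyl on a saturated chain carbon, four bonds along the chain from an aromatic nitrogen.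

For the measured compounds named here, only one measured step bears on this change, and it is a different edit to the same chain. With only a 1.2-fold lower number from compound 1 to compound 2 (0.09 log units; within the scatter) to go on, no step beyond the scatter is expected in this assay, in either direction. Going by the values given here, this is thin evidence, since the data hold no measured pair with this exact change.

The expected step, an estimate only, is a 1.1-fold higher number from compound 2 to compound 3 (0.04 log units; within the scatter). For compound 3 the estimated value is 10000 nM, with an expected range from 5000 nM to 20000 nM.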

Compound 3, concentration for 50% growth inhibition: 20100 nM
Estimate against measurement, compound 3: 2.0-fold (0.30 log units) below, and the stated range ends below it.
By their numbers in this assay, from the lowest: compounds 2, 1 and 3 (each within the scatter of the next, the first and the last beyond it).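

In this assay, among the compounds shown here, hydrogen in place of ethyl on a saturated chain carbon, four bonds along the chain from an aromatic nitrogen, gives the first step at this position that lies beyond the scatter (a 2.2-fold higher number from compound 2 to compound 3 (0.34 log units; beyond the scatter)), although it is a modest one. The second new step, hydrogen in place of methyl on a saturated chain carbon bound to two saturated chain carbons, stays within the scatter (a 1.8-fold higher number from compound 1 to compound 3 (0.25 log units; within the scatter)), so compound 3 stands level with compound 1. For the compounds shown here, the chain can therefore alter the read-out, but only the pair of compound 2 and compound 3 shows this, and compound 1 lies within the scatter of both. Nothing measured here accounts for the step between compound 2 and compound 3 and the reason for it stays unknown.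

The compounds shown leave open whether a longer chain than that of compound 2 would continue this trend or level off. They also leave open how this position would respond to an amine or a carboxylic acid on the chain, since all three compounds carry plain carbon chains there.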